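Aryl ether variation in a thiazolidinedione series

The compounds below may be only part of what the source reports. "The series", "measured", "known", "first", "only" and "open" are said of these compounds alone.

Measured compounds:
compound 1 `Cc1ccc(Oc2ccc(CC3SC(=O)NC3=O)cc2)cc1C`: 727 nM
compound 2 `Cc1ccnc(Oc2ccc(CC3SC(=O)NC3=O)cc2)c1`: 4280 nM
compound 3 `O=C1NC(=O)C(Cc2ccc(Oc3cccc(Cl)c3)cc2)S1`: 318 nM

In a functional assay for agonist activity at Free fatty acid receptor 1 (Homo sapiens), read by FLIPR, in the presence of a further agent that is not named here (on this read-out higher numbers stand for an effect only at larger amounts of compound and lower numbers for an effect already at smaller amounts), compound 3 gives the lowest number of the three. Compound 1 comes nearest to it, and compound 2 stands furthest away; both gaps lie beyond the scatter, so compound 3 is the most potent of the measured set on this read-out.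

For the measured compounds named here, the one measured step that alters the aryl ether is a 13-fold lower number from compound 2 to compound 3 (1.13 log units; beyond the scatter). That step swaps an aromatic ring with a ring nitrogen for a carbon-only ring; it does not by itself tell how one carbon-only ring compares with another.

Compound 4 `Cc1ccc(Oc2ccc(CC3SC(=O)NC3=O)cc2)cc1` is not yet measured. It differs from compound 3 in one place: 4-methylphenyl in place of 3-chlorophenyl on an oxygen on an aromatic ring. Going by the values given here, no measured step covers exactly this exchange. The closest comparison is compound 1, which carries a 3,4-dimethylphenyl on the same oxygen and gives a number somewhat higher than compound 3, beyond the scatter but not by much. Compound 4 is therefore expected to land near compound 1 and compound 3, with a 1.9-fold higher number from compound 3 to compound 4 (0.28 log units; within the scatter) estimated as a small shift, at most a little beyond the scatter. The estimate for compound 4 is 600 nM, in the range 250 nM to 1500 nM.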

Compound 4, half-maximal effective concentration: 547 nM
Estimate against measurement, compound 4: 1.1-fold (0.04 log units) above; measured number inside the range.
By their numbers in this assay, from the lowest: compounds 3, 4 and 1 (each within the scatter of the next, the first and the last beyond it); then compound 2.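

In this assay, for the compounds shown here, a 1.7-fold higher number from compound 3 to compound 4 (0.24 log units; within the scatter) gives the first direct comparison of two carbon-only rings on this oxygen, and 4-methylphenyl and 3-chlorophenyl cannot be told apart there, so chlorine is not required at this level of potency. With a 1.3-fold lower number from compound 1 to compound 4 (0.12 log units; within the scatter), the single methyl exchanged for hydrogen also leaves no readable difference, so the second methyl of compound 1 is not needed to hold that level. The ring nitrogen-bearing group remains the clear outlier: a 7.8-fold lower number from compound 2 to compound 4 (0.89 log units; beyond the scatter) lies beyond the scatter, so the gap first seen with the 3-chlorophenyl ring also appears with a carbon-only ring that carries a methyl, as the 4-methylpyridin-2-yl group does.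

Nothing shown gives a reason for these differences or for the similarity among the carbon-only rings. Open questions are whether a plain phenyl on this oxygen reads like compound 4, and how a methoxy, a trifluoromethyl or an amine on the carbon-only ring would read.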